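Amino in place of nitro in a narrow series

This account rests on a few compounds, and the source may have more. Where it says the series, first, only, none or still open, it means among the compounds named here.

Three compounds on a shared core have numbers in an ADME assay on L6 cells (Rattus norvegicus) for cytotoxicity, read by resazurin assay, with a stated time of 72 h; on this read-out higher numbers stand for weaker inhibition and lower numbers for stronger inhibition: compound 1 `Cc1ccc(C(=O)NC(=O)c2ccccc2O)cc1` gives 46 ug/mL, compound 2 `O=C(NC(=O)c1ccccc1O)c1ccc(F)cc1` gives 38 ug/mL and compound 3 `O=C(NC(=O)c1ccccc1O)c1ccc([N+](=O)[O-])cc1` gives 53 ug/mL. Compound 3 is not separated from the other two, with a 1.2-fold higher number from compound 1 to compound 3 (0.06 log units; within the scatter) and a 1.4-fold higher number from compound 2 to compound 3 (0.14 log units; within the scatter).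

The next compound is compound 4 `Nc1ccc(C(=O)NC(=O)c2ccccc2O)cc1`. Its change from compound 3 is amino in place of nitro on an aromatic carbon, para to a large group: amino in place of nitro on an aromatic carbon.

Going by the values given here, no measured compound carries amino, so the data hold no direct reading on this group. The closest evidence is the set of swaps among the methyl, fluoro and nitro compounds, namely a 1.2-fold lower number from compound 1 to compound 2 (0.08 log units; within the scatter), a 1.2-fold higher number from compound 1 to compound 3 (0.06 log units; within the scatter) and a 1.4-fold higher number from compound 2 to compound 3 (0.14 log units; within the scatter). None of these three swaps moved the number beyond the scatter, although three compounds are a thin basis. A step beyond the scatter is therefore not expected, and no firm direction can be given. The expected change is a 1.2-fold lower number from compound 3 to compound 4 (0.07 log units; within the scatter).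

In this assay the estimate for compound 4 is 45 ug/mL, with an expected range from 24 ug/mL to 85 ug/mL.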

Compound 4, half-maximal inhibitory concentration: 39 ug/mL
Beside the measured number, compound 4's estimate is 1.2-fold (0.06 log units) above it; the measured number falls inside the stated range.
By their numbers in this assay, from the lowest: compounds 2, 4, 1 and 3 (each within the scatter of the next).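

In this assay, amino on the aromatic carbon para to a large group brings a hydrogen-bond donor where nitro has none, yet the series shows a 1.4-fold lower number from compound 3 to compound 4 (0.13 log units; within the scatter) for this change. Going by these compounds alone, the other two swaps into amino read the same way, with a 1.0-fold higher number from compound 2 to compound 4 (0.01 log units; within the scatter) and a 1.2-fold lower number from compound 1 to compound 4 (0.07 log units; within the scatter) as the printed steps, so methyl, fluoro, nitro and amino now form a set of four groups at this position with no step between them beyond the scatter, and the addition of a donor-bearing group does not separate one compound from the rest. No measurement available here offers an explanation for this flat reading.

As far as these compounds go, whether a carboxylic acid, a dimethylamino group or a longer alkyl chain at the same position would stay within the scatter remains open. Also open, from the compounds shown here alone, is whether the flat reading holds for changes elsewhere on the shared core, as all four compounds differ only at this one place.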